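Chloro in Place of Nitro on the Aromatic Carbon

The source may hold more compounds than are shown below. What is called first, only, known or untested is meant among the compounds shown, and "the series" means these compounds.

For the measured compounds named here, compound 1 `CCOC(=O)c1c(Nc2ccc([N+](=O)[O-])cc2)ncnc1NC(C)C` was tested in a functional assay on the whole organism with Rattus norvegicus as the target, at a dose of 50 mg/kg by the oral route (a lower number here means less inhibition, a higher number more inhibition at the dose given (going by the name of the read-out)), where compound 1 gives 84.6%, one of only two numbers on record and within the scatter of the other. That other is compound 2 `CCOC(=O)c1c(Nc2ccc(C)cc2)ncnc1NC(C)C`, which gives 89.7% in this assay; the step of a number 5.1 percentage points higher from compound 1 to compound 2 (within the scatter) changes nothing beyond the scatter. Compound 3 `CCOC(=O)c1c(Nc2ccc(Cl)cc2)ncnc1NC(C)C` differs from compound 1 by chloro in place of nitro on an aromatic carbon. Going by the values given here, only the step to compound 2 bears on this change, and it stayed within the scatter, so no step beyond the scatter is expected in this assay; the expected step is a number 1.4 percentage points higher from compound 1 to compound 3 (within the scatter). Compound 3 is therefore estimated at 86%, between 76% and 96%.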

Compound 3, a percentage reported as inhibition, in the whole organism at one dose (the size of the read-out at that dose, not a potency): 30.9%
For compound 3 the middle estimate is 55.1 percentage points above the measured one; the whole stated range lies above it.
By their numbers in this assay, from the lowest: compound 3; then compounds 1 and 2 (each within the scatter of the next).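

In this assay the group on this aromatic carbon can matter a great deal. Compounds 1 and 2 stayed within the scatter of each other, yet chloro gives a number 53.7 percentage points lower from compound 1 to compound 3 (beyond the scatter) and a number 58.8 percentage points lower from compound 2 to compound 3 (beyond the scatter). The close match between nitro and methyl therefore did not carry over to chloro, and nothing available explains the drop. Open, as far as these compounds go, is whether fluoro, bromo, an amine or a carboxylic acid on this carbon would give a high number like nitro and methyl or a low one like chloro. Also open, from the compounds shown here alone, is whether the drop for chloro would persist at other doses.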